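A few compounds are considered here, and "the series" means these few. Any claim that something is new, unique, unknown or untested is made for them only; others in the source may bear on it.

The three measured compounds share one core and differ only at its edges. In a functional assay on the whole organism with Rattus norvegicus as the target, at a dose of 3 mg/kg by the oral route (a higher number here means a stronger effect of the compound at the dose given, a lower number a weaker effect), compound 1 `CCCOc1cc(C(=O)Nc2nn[nH]n2)nc(-c2ccccc2)c1` gives 100%. Compound 2 `Cc1cc(C(=O)Nc2nn[nH]n2)nc(-c2ccccc2)c1` gives 50% in this assay, the lowest of the three numbers. Compound 3 `Cc1cccc(-c2cc(C)cc(C(=O)Nc3nn[nH]n3)n2)c1` gives 61% in this assay. The measured steps run in both directions: a number 50 percentage points lower from compound 1 to compound 2 (beyond the scatter), while a number 11 percentage points higher from compound 2 to compound 3 (beyond the scatter).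

Compound 4 `Cc1cc(C(=O)Nc2nn[nH]n2)nc(-c2ccc(C(C)C)cc2)c1` has not yet been measured in this assay. It differs from compound 2 in one place: isopropyl in place of hydrogen on an aromatic carbon. Among the measured compounds shown here, no measured step changes the same place. The step of a number 50 percentage points lower from compound 1 to compound 2 (beyond the scatter) concerns a different ring and bears little on this change. The step of a number 11 percentage points higher from compound 2 to compound 3 (beyond the scatter) is the closer analogy, since there too an alkyl group enters on a six-membered aromatic ring of carbon only, although at another carbon and with a smaller group. A modest upward step, or none beyond the scatter, is therefore the reasonable expectation, and nothing in the data points to a large one.

Compound 4 is expected to give about 60% in this assay, with a likely range from 35% to 85%. That estimate means an expected a number 10 percentage points higher from compound 2 to compound 4 (within the scatter).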

Compound 4, a percentage reported as inhibition, in the whole organism at one dose (the size of the read-out at that dose, not a potency): 100%
Compound 4: middle estimate off by 40 percentage points, on the low side; the whole stated range lies below it.
By their numbers in this assay, from the lowest: compound 2; then compound 3; then compounds 1 and 4 (each within the scatter of the next).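

In this assay the isopropyl group, on an aromatic carbon of a six-membered aromatic ring of carbon only and para to a large group, produces a number 50 percentage points higher from compound 2 to compound 4 (beyond the scatter) and so shows that a single alkyl group on this ring can move the read-out strongly. Among the compounds shown here, the only earlier change on this ring, methyl in place of hydrogen at a different carbon, gave the modest a number 11 percentage points higher from compound 2 to compound 3 (beyond the scatter) and a large step had been seen only as a number 50 percentage points lower from compound 1 to compound 2 (beyond the scatter) on a different ring. The data shown offer no measured explanation for the size of this new step.

The compounds shown leave open whether ethyl, tert-butyl or a group of another kind such as methoxy or a carboxylic acid at this same carbon would give a similar effect, and so whether the large step is particular to isopropyl. Compound 4 gives 100% at a single dose, which is the size of an effect and not a potency, so its behaviour at lower doses also remains unsettled.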